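Trifluoromethyl for fluoro: from one core to another

The source may hold more compounds than are shown below. What is called first, only, known or untested is meant among the compounds shown, and "the series" means these compounds.

The measured compounds, with their half-maximal inhibitory concentrations in an ADME assay on THP-1 cells (Homo sapiens) for cytotoxicity, read by flow cytometry and propidium iodide staining, with a stated time of 72 h; on this read-out lower numbers stand for stronger inhibition and higher numbers for weaker inhibition:

Compound 1, `CC(=O)Nc1ccc(O)c(C(=O)/C=C/c2cccc(F)c2)c1`: 78600 nM
Compound 2, `CC(=O)Nc1ccc(O)c(C(=O)/C=C/c2cccc(C(F)(F)F)c2)c1`: 8400 nM
Compound 3, `CC(=O)Nc1ccc2oc(-c3ccc(F)cc3)cc(=O)c2c1`: 22000 nM

Compounds 1 and 2 share one core and differ in a single place. trifluoromethyl in place of fluoro on an aromatic carbon That change gave a 9.4-fold lower number from compound 1 to compound 2 (0.97 log units; beyond the scatter) in this assay.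

Compound 3 is built on a different core. The difference between the two cores is not broken down here. In this assay compound 3 stands between the other two, its number beyond the scatter from each.

Compound 4, `CC(=O)Nc1ccc2oc(-c3ccc(C(F)(F)F)cc3)cc(=O)c2c1`, has not yet been measured in this assay. It is made from compound 3 by the same kind of change that turns compound 1 into compound 2. trifluoromethyl in place of fluoro on an aromatic carbon The surroundings differ: in compound 2 the trifluoromethyl sits meta to a large group, in compound 4 it sits para to a large group, so this is the same kind of change and not the same change.

For the measured compounds named here, only one example of the change exists here, and it sits on another core, so the expectation rests on a single step. Because a 9.4-fold lower number from compound 1 to compound 2 (0.97 log units; beyond the scatter) was clearly beyond the scatter, a step in the same direction is expected from compound 3 to compound 4, though somewhat smaller given the different surroundings: a 6.3-fold lower number from compound 3 to compound 4 (0.80 log units; beyond the scatter) is the estimate. Compound 4 is therefore expected to give about 3500 nM in this assay, most likely between 1200 nM and 12000 nM.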

Compound 4, half-maximal inhibitory concentration: 10000 nM
For compound 4 the middle estimate is 2.9-fold (0.46 log units) below the measured one; measured number inside the range.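

On the core of compound 3, trifluoromethyl in place of fluoro again lowered the number in this assay, giving a 2.2-fold lower number from compound 3 to compound 4 (0.34 log units; beyond the scatter). The direction of the change therefore held on both cores, but its size did not, and the two steps can't be treated as one fixed gain that moves unchanged from core to core: the same change on two cores in this assay, a 9.4-fold lower number (0.97 log units; beyond the scatter) from compound 1 to compound 2 and a 2.2-fold lower number (0.34 log units; beyond the scatter) from compound 3 to compound 4, 4.3-fold (0.63 log units) apart, beyond the scatter of two such steps

For the compounds shown here, this is still only two matched pairs, and they differ both in the core and in where the trifluoromethyl sits on its ring, so these data cannot separate those two influences or say which one goes with the smaller step; nor do they establish a general rule for this series.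

The compounds shown leave open whether the same swap would give a step of the same size with the trifluoromethyl placed elsewhere on the ring of either core, which would pull the core and the position apart. They also leave open how other groups in the same place would compare with fluoro and trifluoromethyl on each core, for example a chlorine atom, a methoxy group or a nitrile.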